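Piperidin-1-yl to 4-methylpiperazin-1-yl: notes on the series

The source may hold more compounds than are shown below. What is called first, only, known or untested is meant among the compounds shown, and "the series" means these compounds.

In an ADME assay on HEK293 cells (Homo sapiens) for inhibition, read by MTT assay, with stated times of 18 h and 4 h (on this read-out higher numbers stand for weaker inhibition and lower numbers for stronger inhibition), compound 1 `CCCCCCCCCCOP(=O)(O)OCCSC(=S)N1CCCCCC1` gives 70000 nM and compound 2 `CCCCCCCCOP(=O)(O)OCCSC(=S)N1CCCCC1` gives 69000 nM on the same read-out. Compound 2 therefore stands level with compound 1, the two values lying within the scatter of each other.

Within the data shown here, compound 3 `CCCCCCCCOP(=O)(O)OCCSC(=S)N1CCN(C)CC1` has 4-methylpiperazin-1-yl in place of piperidin-1-yl on a thiocarbonyl carbon and has no measurement yet. Among the measured compounds shown here, no measured pair shows this change, so the only guide is the level held by compound 2 at 69000 nM in the series so far.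

The expected step of a 1.1-fold higher number from compound 2 to compound 3 (0.04 log units; within the scatter) stays within the scatter in this assay with no direction favoured. For compound 3 the estimated value is 75000 nM with an expected range from 35000 nM to 150000 nM on this read-out.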

Compound 3, half-maximal inhibitory concentration: 86000 nM
The estimate for compound 3 lay 1.1-fold (0.06 log units) below the measured number; low and high end bracket the measured number.
By their numbers in this assay, from the lowest: compounds 2, 1 and 3 (each within the scatter of the next).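

In this assay, among these compounds, the first single-place change at this position gives a 1.2-fold higher number from compound 2 to compound 3 (0.10 log units; within the scatter) and so leaves compound 3 level with compound 2. On a thiocarbonyl carbon, 4-methylpiperazin-1-yl can therefore stand in place of piperidin-1-yl, with its second ring hetero atom and its one hydrogen-bond acceptor, without a step beyond the scatter in this pair. This rests on one pair only, and nothing measured here bears on why the two numbers stay level.

Still open, as far as these compounds go, is whether a more different group on the thiocarbonyl carbon, such as morpholin-4-yl, diethylamino or a ring carrying a carboxylic acid, would move the number beyond the scatter. Also open, from the compounds shown here alone, is whether 4-methylpiperazin-1-yl would hold the same level with a longer chain, such as dodecyl, in place of octyl.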